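Notes on a kinase activator series: compound 1 to compound 4

The compounds below may be only part of what the source reports. "The series", "measured", "known", "first", "only" and "open" are said of these compounds alone.

Measured so far in an assay on isolated protein for activation of cGMP-dependent protein kinase 1 (Homo sapiens), read by ADP-Glo, with stated times of 30 min and 2 h; a lower number here means that less compound is needed, a higher number that more compound is needed for the effect:
compound 1, `COc1cccc([C@@H](CO)O[C@H]2CCCN(Cc3ccc(C(=O)O)cc3C)[C@H]2c2ccccc2)c1`, gives > 200000 nM, which is a limit of the assay.
compound 2, `O=C(O)C12CC(CN3CCC[C@H](O[C@H](CO)c4cc(Cl)cc(Cl)c4)[C@@H]3c3ccccc3)(C1)C2`, gives > 200000 nM, which is a limit of the assay.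
compound 3, `Cc1cc(C(=O)O)ccc1CN1CCC[C@H](O[C@H](CO)c2cc(Cl)cc(Cl)c2)[C@@H]1c1ccc(F)cc1`, gives "nd" (no result reported).

Going by the values given here, compound 1 therefore stands nowhere on a scale of numbers: its value is a limit, and the limit of > 200000 nM in this assay, at which 2 of the 3 values shown sit, is the only evidence across the three entries. Among the compounds with values here, nothing among them yields a single number, and no step between two measured compounds exists to set a size for any change.

The next entry is compound 4, `Cc1cc(C(=O)O)ccc1CN1CCC[C@H](O[C@H](CO)c2cc(Cl)nc(Cl)c2)[C@@H]1c1ccccc1`. Against compound 1 the change is 2,6-dichloropyridin-4-yl in place of 3-methoxyphenyl on a saturated chain carbon bound to an oxygen on a saturated carbon and a saturated chain carbon. The rest of the shared core, the carboxylic acid bearing benzyl arm and the hydroxymethyl chain, are kept.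

Within the data shown here, with no measured step and two limits, the expectation for this assay is that compound 4 most likely again sits at the limit; the step from compound 1 to compound 4 is expected to be an at least 1.3-fold lower number from compound 1 to compound 4 (0.12 log units; that floor lies within the scatter), which is none beyond the scatter. Compound 4 is estimated at 150000 nM, within a range from 20000 nM to 500000 nM, the upper end being the limit itself.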

Compound 4, half-maximal effective concentration: > 200000 nM
Compound 4: a limit, no number; the forecaster's own chance of this, stated with the estimate: 60%; at least 1.3-fold (0.12 log units) between middle value and limit.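

Going by these compounds alone, compound 1 and compound 4 both sit at a limit of the assay, so the exchange of 3-methoxyphenyl for 2,6-dichloropyridin-4-yl gives no step that can be read between them. The compounds shown leave open which structures, if any, give a single number in this assay, and how large any change in this series would be.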